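Swapping piperidin-1-yl for 2-aminoethyl on the side chain

The compounds below may be only part of what the source reports. "The series", "measured", "known", "first", "only" and "open" are said of these compounds alone.

In a functional assay on T-24 cells (Homo sapiens) for cytotoxicity, read by MTT assay, with stated times of 48 h and 4 h (on this read-out higher numbers stand for weaker inhibition and lower numbers for stronger inhibition), compound 1 `COc1ccc(/C=C/c2nc(NCCN(C)C)c3cc(Cl)ccc3n2)cc1OC` gives 12100 nM and compound 2 `COc1ccc(/C=C/c2nc(NCCN3CCCCC3)c3cc(Cl)ccc3n2)cc1OC` gives 7640 nM. These two numbers lie within the scatter of each other, so compound 2 stands level with compound 1. Compound 3 `COc1ccc(/C=C/c2nc(NCCCCN)c3cc(Cl)ccc3n2)cc1OC` has not yet been measured. Its structure departs from that of compound 2 as follows: 2-aminoethyl in place of piperidin-1-yl on a saturated chain carbon, two bonds along the chain from a nitrogen on an aromatic ring. Going by the values given here, the only measured step at this place is a 1.6-fold lower number from compound 1 to compound 2 (0.20 log units; within the scatter), which lies within the scatter. Among the compounds with values here, that step exchanges dimethylamino for piperidin-1-yl, and no measured compound carries 2-aminoethyl there, so the evidence is thin. No change beyond the scatter is therefore expected. The expected step is a 1.0-fold higher number from compound 2 to compound 3 (0.02 log units; within the scatter). For compound 3 the estimated value is 8000 nM, with an expected range of 3000 nM to 20000 nM.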

Compound 3, half-maximal inhibitory concentration: 7820 nM
Compound 3: the middle estimate sits 1.0-fold (0.01 log units) above what was measured, and the stated range covers the measured number.
By their numbers in this assay, from the lowest: compounds 2, 3 and 1 (each within the scatter of the next).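

In this assay, 2-aminoethyl in place of piperidin-1-yl gives a 1.0-fold higher number from compound 2 to compound 3 (0.01 log units; within the scatter), and the same group in place of dimethylamino gives a 1.5-fold lower number from compound 1 to compound 3 (0.19 log units; within the scatter). The earlier pair compared only dimethylamino and piperidin-1-yl; now an open chain with a hydrogen-bond donor, without the six-membered ring, also stays within the scatter at this place on the saturated chain carbon. Nothing available explains why these end groups stand level.

Going by these compounds, it remains open whether a carboxylic acid or a hydroxyl group on this chain, or a morpholin-4-yl ring in place of piperidin-1-yl, would also stay within the scatter. Also open, on these data alone, is whether a longer chain would do so, and whether any of these end groups would behave the same way on a different core.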